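Swapping fluoro for bromo on an enone benzylidene

The compounds below may be only part of what the source reports. "The series", "measured", "known", "first", "only" and "open" are said of these compounds alone.

Two compounds of this series have numbers in a functional assay on P388 cells (Mus musculus) for inhibition (a higher number here means a weaker inhibitor, a lower number a stronger inhibitor), so far. Compound 1 `O=C1/C(=C/c2ccc(Cl)c(Cl)c2)CCCc2ccccc21` gives 12200 nM in this assay, and compound 2 `O=C1/C(=C/c2ccccc2F)Cc2ccccc21` gives 31700 nM, the highest of the two numbers; the gap between them lies beyond the scatter, with compound 1 the lower of the pair. Compound 3 `O=C1/C(=C/c2ccccc2Br)Cc2ccccc21` is the next to be measured. It differs from compound 2 by bromo in place of fluoro on an aromatic carbon, the group sitting on an aromatic carbon of a six-membered aromatic ring of carbon only, ortho to a large group. Going by the values given here, no measured pair here shows what such an exchange does on its own, so the direction rests on little. A modest move towards a lower number is expected, with the step from compound 2 to compound 3 estimated at a 1.6-fold lower number from compound 2 to compound 3 (0.20 log units; within the scatter). Compound 3 is therefore expected to give about 20000 nM in this assay, within a range from 7000 nM to 60000 nM.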

Compound 3, half-maximal inhibitory concentration: > 50000 nM
Compound 3 was reported as a limit; the forecaster's own chance of this, stated with the estimate: 10%; at least 2.5-fold (0.39 log units) between middle value and limit.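

Going by these compounds alone, this is the first comparison that changes only one place: in this assay, bromo in place of fluoro on an aromatic carbon, ortho to a large group, gives an at least 1.5-fold higher number from compound 2 to compound 3 (0.19 log units; that floor lies within the scatter) and no sign of a stronger inhibitor. Compound 3 gives > 50000 nM, which is a limit and not a number. The step is therefore only a floor, and it does not show how far the number rises: the limit of > 50000 nM in this assay, at which 1 of the 3 values shown sits.

From the compounds shown here alone, it remains open how a methoxy or hydroxy group on the same aromatic carbon would read in this assay and whether either would fall below the number of compound 2. Compound 1 differs from compound 2 and compound 3 in more than one place, so it cannot show whether this exchange would behave alike on its core.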